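The source may hold more compounds than are shown below. What is called first, only, known or untested is meant among the compounds shown, and "the series" means these compounds.

Compound 1 `O=c1c(Cc2coc3cccc(OCC4CCCCC4)c3c2=O)coc2ccccc12`: 4510 nM
Compound 2 `CC(C)CCOc1cccc2occ(Cc3coc4ccccc4c3=O)c(=O)c12`: > 10000 nM

In a functional assay on PC-3 cells (Homo sapiens) for antiproliferative activity, read by XTT assay (a higher number here means a weaker inhibitor, a lower number a stronger inhibitor), compound 2 reaches only a limit, > 10000 nM, so its true number is not known. Within the data shown here, the one measured step, an at least 2.2-fold higher number from compound 1 to compound 2 (0.34 log units; beyond the scatter), shows that shrinking the chain on the oxygen weakened inhibition. Compound 3 `O=c1c(Cc2coc3ccccc3c2=O)coc2ccccc12` goes further: hydrogen in place of isopentyloxy on an aromatic carbon. Among the measured compounds shown here, no measured pair covers removing the whole group, and compound 2 itself sits at the limit (the limit of > 10000 nM in this assay, at which 1 of the 2 values shown sits), so only a cautious guess is possible. Compound 3 is expected near 12000 nM, within 3000 nM to 50000 nM, a step that the limit leaves unreadable from compound 2 to compound 3.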

Compound 3, half-maximal inhibitory concentration: 7400 nM
Estimate against measurement, compound 3: 1.6-fold (0.21 log units) above, within the range that was stated.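

With hydrogen on this aromatic carbon and no chain at all, compound 3 cannot be told apart from compound 1, with a 1.6-fold higher number from compound 1 to compound 3 (0.22 log units; within the scatter), so cyclohexylmethoxy shows no measurable gain over hydrogen here. Replacing isopentyloxy with hydrogen gives an at least 1.3-fold lower number from compound 2 to compound 3 (0.13 log units; that floor lies within the scatter), so this change shows no firm gain either. The value of compound 2 is a limit, not a number: the limit of > 10000 nM in this assay, at which 1 of the 3 values shown sits.

Going by these compounds, whether an amine or a carboxylic acid at this position would move the number beyond the scatter remains open.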